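Adding one methyl to compound 2

The compounds below may be only part of what the source reports. "The series", "measured", "known", "first", "only" and "open" are said of these compounds alone.

compound 1 `Cc1ccc(S(=O)(=O)c2nc3ccccc3nc2N2CCCC2)cc1` – 9720 nM
compound 2 `O=S(=O)(c1ccccc1)c1nc2ccccc2nc1N1CCCC(O)C1` – 3020 nM

In a functional assay on HL-60 cells (Homo sapiens) for cytotoxicity, read by MTT assay, with a stated time of 72 h (a lower number here means a stronger inhibitor, a higher number a weaker inhibitor), compound 2 gives 3020 nM and holds the lower of the two numbers, while compound 1 gives 9720 nM with a gap beyond the scatter. Compound 3 `Cc1ccc(S(=O)(=O)c2nc3ccccc3nc2N2CCCC(O)C2)cc1` differs from compound 2 in one place, with methyl in place of hydrogen on an aromatic carbon, para to a large group, so that phenyl becomes 4-methylphenyl: methyl in place of hydrogen on an aromatic carbon and nothing else. Among the compounds with values here, no measured pair shows this change alone, so the data give no direct size for it. In this assay the number is expected to move little, perhaps slightly upward, and most likely not beyond the scatter. The expected change is a 1.2-fold higher number from compound 2 to compound 3 (0.06 log units; within the scatter) and no larger. For compound 3 the estimated value is 3500 nM, with an expected range from 1500 nM to 8000 nM in this estimate.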

Compound 3, half-maximal inhibitory concentration: 6080 nM
Compound 3: the middle estimate sits 1.7-fold (0.24 log units) below what was measured, and the stated range covers the measured number.
By their numbers in this assay, from the lowest: compounds 2, 3 and 1 (each within the scatter of the next, the first and the last beyond it).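

In this assay, methyl in place of hydrogen on the aromatic carbon, para to a large group, gives a 2.0-fold higher number from compound 2 to compound 3 (0.30 log units; within the scatter), the first direct size for phenyl becoming 4-methylphenyl, and this single pair shows no change that can be told from the scatter. Within the data shown here, with 4-methylphenyl held in place, 3-hydroxypiperidin-1-yl in place of pyrrolidin-1-yl gives a 1.6-fold lower number from compound 1 to compound 3 (0.20 log units; within the scatter), so this change, which no earlier pair isolated, also stays within the scatter. Nothing measured here speaks to the reason for either step.

From the compounds shown here alone, whether another group on this carbon, such as an amine, a carboxylic acid or a longer chain, would move the number beyond the scatter remains open. Also open, going by these compounds, is whether methyl gives a step of the same size when pyrrolidin-1-yl stands in place of 3-hydroxypiperidin-1-yl.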